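The compounds below may be only part of what the source reports. "The series", "measured", "known", "first", "only" and "open" are said of these compounds alone.

In a functional assay on HeLa cells (Homo sapiens) for cytotoxicity, read by MTT assay, with a stated time of 48 h, tested at 25 uM (on this read-out lower numbers stand for a weaker effect and higher numbers for a stronger effect at the one concentration tested), two compounds of one shared core have been measured. Compound 1 `CS(=O)(=O)c1ccc(Cc2n[nH]c(=S)n2/N=C/c2ccccc2Cl)cc1` gives 36.3%, and compound 2 `CS(=O)(=O)c1ccc(Cc2n[nH]c(=S)n2/N=C/c2c(F)cccc2Cl)cc1` gives 55.3%. Going by the values given here, compound 2 therefore stands highest of the two numbers, and its only neighbour, compound 1, lies lower by the step of a number 19 percentage points higher from compound 1 to compound 2 (beyond the scatter), which came with fluoro in place of hydrogen on an aromatic carbon.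

Compound 3 `CS(=O)(=O)c1ccc(Cc2n[nH]c(=S)n2/N=C/c2ccccc2F)cc1` is not yet measured. It differs from compound 2 by hydrogen in place of chloro on an aromatic carbon. Among the compounds with values here, no measured step removes a chloro group, so the one step on record, a number 19 percentage points higher from compound 1 to compound 2 (beyond the scatter), bears only indirectly on this change, showing that a single halogen on that ring shifted the read-out modestly. Compound 3 keeps the fluoro group but loses the chloro group, and a modest drop is expected, the step of a number 13.3 percentage points lower from compound 2 to compound 3 (beyond the scatter). Compound 3 is estimated at 42%, within a range from 26% to 58%.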

Compound 3, a percentage reported as activity, at one concentration (the size of the read-out at that concentration, not a potency): 14%
Compound 3: middle estimate off by 28 percentage points, on the high side; measured number below the stated range.
By their numbers in this assay, from the lowest: compound 3; then compound 1; then compound 2.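

Read in this assay, the chloro group on this ring proves to matter far more than the first step suggested: removing it gives a number 41.3 percentage points lower from compound 2 to compound 3 (beyond the scatter), a large step, whereas the earlier gain on adding the fluoro group was only modest. With a single halogen on the ring the two are not interchangeable, since fluoro in place of chloro gives a number 22.3 percentage points lower from compound 1 to compound 3 (beyond the scatter), so among these three compounds, those that carry the chloro group read higher than the one that lacks it. Nothing measured here explains why these changes have such different sizes.

From the compounds shown here alone, whether a methyl group, a methoxy group or bromo in the chloro group's place would keep the read-out remains open. So does the question of how the phenyl ring would behave with no halogen at all, and a single concentration gives no potency for any of the three compounds.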